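Chloro to methoxy on two related triazole cores

This account rests on a few compounds, and the source may have more. Where it says the series, first, only, none or still open, it means among the compounds named here.

Compound 1 `S=C(Nc1ccc(Cl)cc1)Nn1c(S)nnc1-c1ccncc1` and compound 2 `COc1ccc(NC(=S)Nn2c(S)nnc2-c2ccncc2)cc1` share one core and differ only by the change (methoxy in place of chloro on an aromatic carbon). In a functional assay on HA22T cells (Homo sapiens) for cytotoxicity, read by sulforhodamine B assay, with a stated time of 24 h (a higher number here means a weaker inhibitor, a lower number a stronger inhibitor), compound 1 gives 2010 nM and compound 2 gives 2370 nM, so that the step of a 1.2-fold higher number from compound 1 to compound 2 (0.07 log units; within the scatter) is small and the two values cannot be told apart. Compound 3 `Clc1ccc(Nc2nn3c(-c4ccncc4)nnc3s2)cc1` carries the same 4-chlorophenyl amine on a different core; the difference between the two cores is not broken down here. In this assay compound 3 gives 3070 nM, a value within the scatter of both compound 1 and compound 2, so no ordering among the three is claimed.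

Compound 4 `COc1ccc(Nc2nn3c(-c4ccncc4)nnc3s2)cc1` is not yet measured. It differs from compound 3 by methoxy in place of chloro on an aromatic carbon, which is the same change as that between compound 1 and compound 2, at a place described in the same words. The expectation for compound 4 therefore rests on the pair already measured: because the step of a 1.2-fold higher number from compound 1 to compound 2 (0.07 log units; within the scatter) stayed within the scatter, the step of a 1.1-fold higher number from compound 3 to compound 4 (0.06 log units; within the scatter) is expected to be of similar size, near flat. In this assay, for the measured compounds named here, compound 4 is estimated at 3500 nM, with a range from 1800 nM to 7000 nM that allows for the usual spread of repeated measurements and for the single precedent.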

Compound 4, half-maximal inhibitory concentration: 282 nM
The estimate for compound 4 lay 12-fold (1.09 log units) above the measured number; measured number below the stated range.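

In this assay, methoxy in place of chloro gives an 11-fold lower number from compound 3 to compound 4 (1.04 log units; beyond the scatter), and this large step does not match the near-flat result of the same change on the core of compound 1: the same change on two cores in this assay, a 1.2-fold higher number (0.07 log units; within the scatter) from compound 1 to compound 2 and an 11-fold lower number (1.04 log units; beyond the scatter) from compound 3 to compound 4, 13-fold (1.11 log units) apart, beyond the scatter of two such steps. In this series, then, the outcome of this change depends on the core that carries it, so a step read on the core of compound 1 is not a reliable guide to the step on the core of compound 3. This rests on one pair for each core, however, and it shows neither which feature of the two cores accounts for the gap nor whether the large step would recur on any further core.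

The compounds shown carry only chloro and methoxy at this place, so it remains open whether the large step is particular to methoxy or would also appear on the core of compound 3 with a hydroxyl, an amine or an ethoxy group. On these data alone, it also remains open whether those same groups would stay as flat on the core of compound 1 as methoxy did, which would show whether the gap between the two cores holds beyond this one change.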